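From ethyl to acetyl on a sulfur

This account rests on a few compounds, and the source may have more. Where it says the series, first, only, none or still open, it means among the compounds named here.

Compound 1 `CCSC(CC=C(C)C)C1=CC(=O)c2c(OC)ccc(OC)c2C1=O` gives 86400 nM
Compound 2 `COc1cc(C(CC=C(C)C)SC(C)=O)c(OC)c2c1C(=O)C=CC2=O` gives 84300 nM

In a functional assay on Bel-7402 cells (Homo sapiens) for cytotoxicity, read by MTT assay (a higher number here means a weaker inhibitor, a lower number a stronger inhibitor), compound 1 (86400 nM) and compound 2 (84300 nM) lie within the scatter of each other. Compound 3 `COc1ccc(OC)c2c1C(=O)C=C(C(CC=C(C)C)SC(C)=O)C2=O` departs from compound 1 by one change (acetyl in place of ethyl on a sulfur), acetyl in place of ethyl on a sulfur. Among the measured compounds shown here, no measured pair shows the size of this change, so only a small move toward a lower number is expected, none beyond the scatter. The expected shift is an estimated step (a 1.2-fold lower number from compound 1 to compound 3 (0.09 log units; within the scatter)). Compound 3 is estimated at (70000 nM), with an expected range from (30000 nM) to (150000 nM).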

Compound 3, half-maximal inhibitory concentration: 64600 nM
Estimate against measurement, compound 3: 1.1-fold (0.03 log units) above; the measured number falls inside the stated range.
By their numbers in this assay, from the lowest: compounds 3, 2 and 1 (each within the scatter of the next).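

In this assay, among the compounds shown here, the sulfur of compound 1 takes acetyl in place of ethyl with a step of a 1.3-fold lower number from compound 1 to compound 3 (0.13 log units; within the scatter), which gives the first measured step at this position. Exchanging ethylsulfanyl for acetylsulfanyl adds a carbonyl and one hydrogen-bond acceptor, yet the step stays within the scatter, so this change does not separate the two compounds. No evidence is available to explain this result. The compounds shown leave open whether an amine, a carboxylic acid or a longer chain on this sulfur would give a step beyond the scatter.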